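Bromo for pentyl on a urea scaffold in rice

This account rests on a few compounds, and the source may have more. Where it says the series, first, only, none or still open, it means among the compounds named here.

Compound 1 `CC(C)c1cccc(NC(=O)N[C@@H](C)c2ccccc2)c1` — 95%
Compound 2 `CCCCCc1ccc(NC(=O)N[C@H](C)c2ccccc2)cc1` — 100%
Compound 3 `CCCCCc1ccc(NC(=O)N[C@@H](C)c2ccccc2)cc1` — 98%

Three ureas have been tested in an ADME assay on the whole organism with Oryza sativa as the target, tested at 0.1 uM; on this read-out lower numbers stand for a stronger effect and higher numbers for a weaker effect at the one concentration tested. Compound 1 gives 95%, compound 2 gives 100% and compound 3 gives 98%. Compound 3 stands second of the three numbers, but its distance to compound 2 and to compound 1 is within the scatter in both cases, so no ordering among them can be claimed. For the measured compounds named here, the one measured step, a number 2 percentage points lower from compound 2 to compound 3 (within the scatter), rests on the fact that compounds 2 and 3 differ only in the configuration as drawn and shows no effect beyond the scatter.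

Compound 4 `C[C@H](NC(=O)Nc1ccc(Br)cc1)c1ccccc1` is not yet measured. It differs from compound 3 by bromo in place of pentyl on an aromatic carbon. Going by the values given here, none of the measured steps touches the pentyl group or its replacement; the only step on record concerns configuration, which does not bear on this change. Among the compounds with values here, there is thus no measured basis for expecting a step of any particular size or direction in this assay, and the three numbers so far all sit near the weak end of the read-out.

Compound 4 is therefore expected to give about 96%, with a range from 80% to 105%. The step this estimate implies is expected to be a number 2 percentage points lower from compound 3 to compound 4 (within the scatter), which is within the scatter.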

Compound 4, a percentage reported as activity, at one concentration (the size of the read-out at that concentration, not a potency): 98%
Beside the measured number, compound 4's estimate is 2 percentage points below it; the measured number falls inside the stated range.
By their numbers in this assay, from the lowest: compounds 1, 3, 4 and 2 (each within the scatter of the next).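

In this assay, the exchange of pentyl for bromo on an aromatic carbon, para to a large group, gives no change at the digits printed from compound 3 to compound 4 (within the scatter). For the compounds shown here, this is the first measured change at this position, and it shows that going from a chain of 5 carbon atoms to a single bromine atom does not register in the number, though with both compounds near the weak end of the read-out, the result shows only that neither group gives a strong effect here. Nothing on record explains the absence of a step, as the only supporting observation concerns configuration and not this exchange.

The compounds shown leave open whether an amine, a carboxylic acid or a longer chain on this aromatic carbon would move the number beyond the scatter in either direction. Going by these compounds alone, also open is whether configuration matters once bromo stands in place of pentyl, as the one step on configuration, a number 2 percentage points lower from compound 2 to compound 3 (within the scatter), belongs to the pentyl pair.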